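The compounds below may be only part of what the source reports. "The series", "measured", "known", "first", "only" and "open" are said of these compounds alone.

Compound 1 `COc1ncnc2c1c(-c1ccoc1)cn2[C@@H]1O[C@H](CO)[C@@H](O)[C@H]1O`, in an ADME assay on MRC5 cells (Homo sapiens), read by MTT assay, with a stated time of 72 h (a lower number here means a stronger inhibitor, a higher number a weaker inhibitor), gives 29400 nM. Compound 2 `COc1ncnc2c1c(-c1cccs1)cn2[C@@H]1O[C@H](CO)[C@@H](O)[C@H]1O` gives 43200 nM in this assay, after (thiophen-2-yl in place of furan-3-yl on an aromatic carbon), a move of a 1.5-fold higher number from compound 1 to compound 2 (0.17 log units; within the scatter). For compound 3 `CSc1ncnc2c1c(-c1ccoc1)cn2[C@@H]1O[C@H](CO)[C@@H](O)[C@H]1O` this assay reports only > 100000 nM, which is a limit of the assay and not a number. The cores of compound 1 and compound 3 differ by methylsulfanyl in place of methoxy on an aromatic carbon, and the step is an at least 3.4-fold higher number from compound 1 to compound 3 (0.53 log units; beyond the scatter). Compound 4 `CSc1ncnc2c1c(-c1cccs1)cn2[C@@H]1O[C@H](CO)[C@@H](O)[C@H]1O` has not yet been measured; it carries thiophen-2-yl in place of furan-3-yl on an aromatic carbon, the same change as from compound 1 to compound 2. Because the limit of > 100000 nM in this assay, at which 1 of the 3 values shown sits, already holds compound 3, the same change applied here is expected to give about a step that the limit leaves unreadable from compound 3 to compound 4. Compound 4 is therefore estimated at 150000 nM, plausibly between 60000 nM and 400000 nM, most likely again reported as a limit.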

Compound 4, half-maximal inhibitory concentration: > 100000 nM
Compound 4 gave a limit, no number (the forecaster's own chance of this, stated with the estimate: 80%); the middle value is on the limit's open side.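

Compound 4 gives > 100000 nM in this assay, which is a limit of the assay and not a number. As far as these compounds go, the step from compound 3 to compound 4 cannot be read, so it remains unknown whether thiophen-2-yl in place of furan-3-yl behaves on the methylsulfanyl core as it does on the methoxy core. Methylsulfanyl in place of methoxy gives an at least 2.3-fold higher number from compound 2 to compound 4 (0.36 log units; beyond the scatter), which points the same way with either five-membered ring, though its true size stays hidden: the same change on two cores in this assay, an at least 3.4-fold higher number (0.53 log units; beyond the scatter) from compound 1 to compound 3 and an at least 2.3-fold higher number (0.36 log units; beyond the scatter) from compound 2 to compound 4; the limit leaves it open whether they differ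

The compounds shown leave open how an amine or a longer chain such as ethoxy in place of methoxy would read in this assay. They also leave open how a phenyl group in place of furan-3-yl would read there.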